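Hydroxy to Amino: Expected Step for Compound 4

This account rests on a few compounds, and the source may have more. Where it says the series, first, only, none or still open, it means among the compounds named here.

Three measured compounds share one core. Compound 1 `COc1ccc(-c2cc3ccccc3c(-c3cccc(O)c3)n2)cc1` gives 1200 nM in a functional assay on HCT-15 cells (Homo sapiens) for cytotoxicity, read by CCK-8 assay and cell counting, with a stated time of 72 h; a higher number here means a weaker inhibitor, a lower number a stronger inhibitor. Compound 2 `COc1cc(OC)cc(-c2cc3ccccc3c(-c3cccc(OC)c3)n2)c1` gives 1170 nM in this assay. Compound 3 `COc1ccc(-c2cc3cc(C)ccc3c(-c3cccc(O)c3)n2)cc1OC` gives 370 nM in this assay, the lowest of the three numbers; its gap to compound 2 and its gap to compound 1 each lie beyond the scatter, so compound 3 is the most potent of the set. Going by the values given here, no two measured compounds differ in one place only, so no single step has been isolated from the measured data.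

Compound 4 `COc1ccc(-c2cc3cc(C)ccc3c(-c3cccc(N)c3)n2)cc1OC` is not yet measured. It differs from compound 3 by amino in place of hydroxy on an aromatic carbon. Among the compounds with values here, the measured set holds no step of this kind, so the expectation rests on the change alone: a small step, most likely none beyond the scatter of this assay, with a lean toward a somewhat higher number. Compound 4 is expected to give 550 nM in this assay, within 180 nM to 1700 nM. The expected step from compound 3 to compound 4 is a 1.5-fold higher number from compound 3 to compound 4 (0.17 log units; within the scatter).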

Compound 4, half-maximal inhibitory concentration: 2700 nM
For compound 4 the middle estimate is 4.9-fold (0.69 log units) below the measured one; the whole stated range lies below it.
By their numbers in this assay, from the lowest: compound 3; then compounds 2 and 1 (each within the scatter of the next); then compound 4.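

Going by these compounds alone, the change from 3-hydroxyphenyl to 3-aminophenyl is the first single-place comparison, and in this assay it gives a 7.3-fold higher number from compound 3 to compound 4 (0.86 log units; beyond the scatter) on the shared core. This position therefore responds to the identity of the group it carries: hydroxy and amino have the same counts of heavy atoms, hydrogen-bond donors and hydrogen-bond acceptors, yet the two compounds differ beyond the scatter. Those counts alone therefore do not set the value here, and no measured finding in hand accounts for the size of the step.

Open, going by these compounds, is whether this step is specific to amino or follows any replacement of hydroxy, which a methylamino group or a carboxylic acid at this place would help to separate. Also open, on these data alone, is whether the step carries over to the core of compound 1.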